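Replacing Isobutyl with Cycloheptyl on the Aromatic Nitrogen

The compounds below may be only part of what the source reports. "The series", "measured", "known", "first", "only" and "open" are said of these compounds alone.

compound 1 `CC(C)c1onc(-c2c(Cl)cccc2Cl)c1COc1ccc(-c2nc3ccc(C(=O)O)cc3n2CC(C)(C)C)cc1` in an assay on Huh-7 cells for agonist activity at Bile acid receptor (Homo sapiens), read by a luciferase reporter; on this read-out lower numbers stand for an effect already at smaller amounts and higher numbers for an effect only at larger amounts of compound: 13 nM
compound 2 `CC(C)Cn1c(-c2ccc(OCc3c(-c4c(Cl)cccc4Cl)noc3C(C)C)cc2)nc2ccc(C(=O)O)cc21` in this assay: 5.26 nM

For the measured compounds named here, compound 2 holds the lowest of the two numbers in this assay, its only neighbour being compound 1. Going by the values given here, the one measured step, a 2.5-fold lower number from compound 1 to compound 2 (0.39 log units; beyond the scatter), comes with hydrogen in place of methyl on a saturated chain carbon. Compound 3 `CC(C)c1onc(-c2c(Cl)cccc2Cl)c1COc1ccc(-c2nc3ccc(C(=O)O)cc3n2C2CCCCCC2)cc1` carries cycloheptyl in place of isobutyl on an aromatic nitrogen. Among the compounds with values here, no measured step swaps a chain for a ring on the aromatic nitrogen, so that step gives only loose guidance; compound 3 is expected to stay near compound 2, with a 1.1-fold higher number from compound 2 to compound 3 (0.06 log units; within the scatter) as the estimated step. Compound 3 is estimated at 6 nM in this assay, within 2 nM to 25 nM.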

Compound 3, half-maximal effective concentration: 14.8 nM
Compound 3: middle estimate off by 2.5-fold (0.39 log units), on the low side; the range from low to high includes it.
By their numbers in this assay, from the lowest: compound 2; then compounds 1 and 3 (each within the scatter of the next).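

Putting a ring on the aromatic nitrogen does not keep the level of the isobutyl compound: in this assay, cycloheptyl in place of isobutyl gives a clear loss (a 2.8-fold higher number from compound 2 to compound 3 (0.45 log units; beyond the scatter)). Cycloheptyl in place of neopentyl, by contrast, leaves the two compounds within the scatter (a 1.1-fold higher number from compound 1 to compound 3 (0.06 log units; within the scatter)), so among these three groups only isobutyl stands apart at this position. Nothing measured here offers an explanation for this.

The compounds shown leave open whether a smaller ring, such as cyclopentyl or cyclopropyl, would read like isobutyl or like cycloheptyl. From the compounds shown here alone, how a straight chain such as n-butyl would read on this nitrogen also remains open.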